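The source may report more compounds than this note shows. Statements on the series, on what has been measured and on what is new or still open speak of the compounds shown alone.

Three compounds have been measured in a functional assay (muscle tissue) with Cavia porcellus as the target; on this read-out lower numbers stand for an effect already at smaller amounts and higher numbers for an effect only at larger amounts of compound:
compound 1 `COC(=O)C1=C(C)N=C(C)/C(=C(\O)OC)C1c1ccccc1I` gives 46.8 nM;
compound 2 `COC(=O)C1=C(C)N=C(C)/C(=C(\O)OC)C1c1cc([N+](=O)[O-])ccc1Cl` gives 30.2 nM;
compound 3 `COC(=O)C1=C(C)N=C(C)/C(=C(/O)OC)C1c1cccc(Cl)c1` gives 15.9 nM.

Compound 1 stands with the highest of the three numbers. Compound 2 lies nearest, with a gap that falls within the usual scatter, so the two cannot be told apart on this read-out. Compound 3 lies furthest, with a lower number beyond the scatter, so compound 3 shows its effect already at a smaller amount than compound 1. Among the compounds with values here, no two of the measured compounds differ in only one place, so no single structural step has been measured.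

Within the data shown here, compound 4 `COC(=O)C1=C(C)N=C(C)/C(=C(\O)OC)C1c1ccccc1F` is the one compound not yet measured. It differs from compound 1 in one place: fluoro in place of iodo on an aromatic carbon. The change sits ortho to a large group; read one bond further out, it turns 2-iodophenyl into 2-fluorophenyl.

Among the measured compounds shown here, nothing among the measured compounds shows how exchanging iodo for fluoro moves this read-out. For compound 4 the expected step of a 1.3-fold higher number from compound 1 to compound 4 (0.11 log units; within the scatter) is therefore none beyond the scatter, and the range is kept wide. Compound 4 is estimated at 60 nM, with a range from 20 nM to 180 nM.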

Compound 4, half-maximal effective concentration: 42.7 nM
Compound 4: the middle estimate sits 1.4-fold (0.15 log units) above what was measured, within the range that was stated.
By their numbers in this assay, from the lowest: compounds 3, 2, 4 and 1 (each within the scatter of the next, the first and the last beyond it).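

In this assay, within the data shown here, the exchange of iodo for fluoro gives a 1.1-fold lower number from compound 1 to compound 4 (0.04 log units; within the scatter) and is the only single structural step that can be read so far. On this aromatic carbon, ortho to a large group, 2-iodophenyl and 2-fluorophenyl therefore cannot be told apart on this read-out, so this position accepts either of these two halogens in the core of compound 1. No outside measurement is available to explain why the two compounds stand level.

Going by these compounds, whether the position accepts only halogens stays open: an amine or a carboxylic acid on the same aromatic carbon could give a very different number. Also open, on these data alone, is whether the same exchange would read alike at another place on the aromatic ring, or in a compound that also carries a nitro group.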